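A few compounds are considered here, and "the series" means these few. Any claim that something is new, unique, unknown or untested is made for them only; others in the source may bear on it.

Going by the values given here, compound 1 `CCOC(=O)c1cccc(Nc2ccnc(-c3ccncc3)n2)c1` is one of three compounds measured in a physicochemical assay for solubility, in phosphate buffer; a higher number here means a more soluble compound, a lower number a less soluble compound. In this assay compound 1 gives 46000 nM, the highest of the three numbers. Compound 2 `CC(=O)c1ccc(Nc2ccnc(-c3ccncc3)n2)cc1` gives 37000 nM, which lies within the scatter of the number for compound 1. Compound 3 `CC(=O)c1ccc(Nc2cc(C)nc(-c3ccncc3)n2)cc1` gives 6000 nM, and the gap from compound 1 to compound 3 lies beyond the scatter. Among the compounds with values here, the only step between two measured compounds that differ in one place is a 6.2-fold lower number from compound 2 to compound 3 (0.79 log units; beyond the scatter), a change of methyl for hydrogen on the core that both share.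

Compound 4 `CCOC(=O)c1cccc(Nc2ccnc(-c3cccnc3)n2)c1` is not yet measured. It differs from compound 1 by pyridin-3-yl in place of pyridin-4-yl on an aromatic carbon. Within the data shown here, no measured step concerns the attached pyridine; the step from compound 2 to compound 3 changes a different part of the shared core and does not speak to the swap of pyridin-4-yl for pyridin-3-yl. The data therefore give no ground for a step beyond the scatter in either direction, and the expectation for compound 4 is a number close to that of compound 1.

On this basis compound 4 is expected to give 45000 nM in this assay, with a range from 20000 nM to 100000 nM. The expected step is a 1.0-fold lower number from compound 1 to compound 4 (0.01 log units; within the scatter).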

Compound 4, solubility: 92000 nM
For compound 4 the middle estimate is 2.0-fold (0.31 log units) below the measured one; the measured number falls inside the stated range.
By their numbers in this assay, from the lowest: compound 3; then compounds 2, 1 and 4 (each within the scatter of the next, the first and the last beyond it).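

Going by these compounds alone, the first step to touch the attached pyridine is read in this assay as a 2.0-fold higher number from compound 1 to compound 4 (0.30 log units; within the scatter) and stays within the scatter, so at this place, on an aromatic carbon between two ring nitrogen atoms, this pair does not separate pyridin-3-yl from pyridin-4-yl. Within the data shown here, the two groups have the same counts of heavy atoms, donors and acceptors, so the pair isolates the place at which the pyridine is joined, which no earlier compound had varied. Among these compounds, the only earlier step, a 6.2-fold lower number from compound 2 to compound 3 (0.79 log units; beyond the scatter) and beyond the scatter, concerned a methyl on a different part of the shared core, and the new step adds a change at this position that stays within the scatter. No measurement at hand explains why the numbers for this pair stand as they do.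

From the compounds shown here alone, whether pyridin-2-yl or a plain phenyl ring at this place would also stay within the scatter of compound 1 remains open. So does whether the same swap of pyridin-4-yl for pyridin-3-yl would give a step of similar size alongside the acetyl group of compound 2 or the added methyl of compound 3.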